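Swapping a Heteroaryl Sulfide for a Phenoxy Group

The source may hold more compounds than are shown below. What is called first, only, known or untested is meant among the compounds shown, and "the series" means these compounds.

Among the compounds with values here, compound 2 `COc1ccc(CN(C(=O)CSc2nncs2)c2cc(OC)c(OC)c(OC)c2)cc1` holds the lowest of the two numbers measured so far in a functional assay on PC-3 cells (Homo sapiens) for antiproliferative activity, read by MTT assay, with a stated time of 48 h (on this read-out lower numbers stand for stronger inhibition and higher numbers for weaker inhibition), at 5530 nM. Within the data shown here, its only neighbour, compound 1 `COc1ccc(CN(C(=O)CSc2nnnn2C)c2cc(OC)c(OC)c(OC)c2)cc1`, gives 10500 nM in this assay, and a 1.9-fold lower number from compound 1 to compound 2 (0.28 log units; within the scatter), so the two cannot be ordered against each other. Compound 3 `COc1ccc(CN(C(=O)COc2ccccc2)c2cc(OC)c(OC)c(OC)c2)cc1` differs from compound 2 in one place: phenoxy in place of (1,3,4-thiadiazol-2-yl)sulfanyl on a saturated chain carbon bound to a carbonyl carbon. Among the measured compounds shown here, the single measured step exchanged one ring on the sulfur for another and stayed within the scatter; no measured step removes the sulfur or introduces a phenoxy group, so there is no direct precedent for this change. The expectation is therefore a 1.1-fold higher number from compound 2 to compound 3 (0.04 log units; within the scatter), with no shift beyond the scatter anticipated. For compound 3 the estimate in this assay is 6000 nM, with a range from 2000 nM to 20000 nM.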

Compound 3, half-maximal inhibitory concentration: 19700 nM
Compound 3: middle estimate off by 3.3-fold (0.52 log units), on the low side, within the range that was stated.
By their numbers in this assay, from the lowest: compounds 2, 1 and 3 (each within the scatter of the next, the first and the last beyond it).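

In this assay, within the data shown here, phenoxy in place of (1,3,4-thiadiazol-2-yl)sulfanyl on a saturated chain carbon bound to a carbonyl carbon gives a 3.6-fold higher number from compound 2 to compound 3 (0.55 log units; beyond the scatter), the only step at this position that lies beyond the scatter, and a modest one. Measured from the other sulfide, phenoxy in place of (1-methyl-1H-tetrazol-5-yl)sulfanyl gives a 1.9-fold higher number from compound 1 to compound 3 (0.27 log units; within the scatter), so the exchange registers beyond the scatter from one sulfide and not from the other. Nothing available explains this result.

The compounds shown leave open whether the ring or the linking atom carries the shift, since phenoxy changes both at once; phenylsulfanyl or 1,3,4-thiadiazol-2-yloxy would separate the two. Also open, from the compounds shown here alone, is how an amine or a carboxylic acid at this place would read in this assay.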